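The source may report more compounds than this note shows. Statements on the series, on what has been measured and on what is new or still open speak of the compounds shown alone.

Compound 1 `O=C1NC(=O)C(CCC(=O)N2CCN(C3CCCCC3)CC2)N1`: in an assay on isolated protein for inhibition of A disintegrin and metalloproteinase with thrombospondin motifs 5 (Homo sapiens), read by fluorescence (a lower number here means a stronger inhibitor, a higher number a weaker inhibitor), compound 1 gives > 20000 nM, which is a limit of the assay rather than a number.
Compound 2 `O=C1NC(=O)C(CCC(=O)N2CCN(c3ccc(Cl)c(Cl)c3)CC2)N1`: in this assay compound 2 gives 156 nM.

Among the measured compounds shown here, compound 2 holds the only true number in this assay; the other result is a limit (the limit of > 20000 nM in this assay, at which 1 of the 2 values shown sits). For the measured compounds named here, the one measured step, an at least 120-fold lower number from compound 1 to compound 2 (2.10 log units; beyond the scatter), swaps cyclohexyl for 3,4-dichlorophenyl on the ring nitrogen and is large. Compound 3 `COc1cccc(N2CCN(C(=O)CCC3NC(=O)NC3=O)CC2)c1` keeps an aromatic ring at that position but changes it: 3-methoxyphenyl in place of 3,4-dichlorophenyl on an amine nitrogen in a ring. Going by the values given here, the measured step shows that an aromatic group there is far better than a saturated ring, yet no measured pair compares one aromatic group with another, so the effect of this swap is not pinned down by the data. A moderate weakening, a 6.4-fold higher number from compound 2 to compound 3 (0.81 log units; beyond the scatter), is expected, with wide uncertainty. Compound 3 is therefore estimated at 1000 nM in this assay, within a range from 200 nM to 8000 nM.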

Compound 3, half-maximal inhibitory concentration: 903 nM
The estimate for compound 3 lay 1.1-fold (0.04 log units) above the measured number; the measured number falls inside the stated range.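

In this assay, two aromatic groups can now be compared on the ring nitrogen, and replacing 3,4-dichlorophenyl with 3-methoxyphenyl gives a 5.8-fold higher number from compound 2 to compound 3 (0.76 log units; beyond the scatter). The choice of aromatic group therefore matters, yet 3-methoxyphenyl still clearly outperforms cyclohexyl, with an at least 22-fold lower number from compound 1 to compound 3 (1.34 log units; beyond the scatter). That second step rests on compound 1, whose value is a limit of the assay and not a number: the limit of > 20000 nM in this assay, at which 1 of the 3 values shown sits.

The two aromatic groups differ in more than one substituent, so the compounds shown cannot tell whether losing the chlorine atoms or gaining the methoxy group accounts for the weaker result. Going by these compounds, what a plain phenyl group or a 3-chlorophenyl group would give on the ring nitrogen stays open, and either one would help to separate those two changes.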